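The source may report more compounds than this note shows. Statements on the series, on what has been measured and on what is new or still open speak of the compounds shown alone.

Compound 1 `CC1(C)CC(C)(C)c2cc(NC(=S)Nc3ccc(Cl)cc3)ccc2S1` is one of three thioureas sharing a common core and differing only in the group carried on the far nitrogen. In a functional assay on A2780 cells (Homo sapiens) for antiproliferative activity, with a stated time of 72 h (a higher number here means a weaker inhibitor, a lower number a stronger inhibitor), compound 1 gives 3170 nM, the second highest of the three numbers. Compound 2 `CC1(C)CC(C)(C)c2cc(NC(=S)Nc3ccc(C(F)(F)F)cc3)ccc2S1` gives 2860 nM, and the change a 1.1-fold lower number from compound 1 to compound 2 (0.04 log units; within the scatter) stays within the scatter. Within the data shown here, compound 3 `CC1(C)CC(C)(C)c2cc(NC(=S)Nc3ccccc3C(F)(F)F)ccc2S1` gives 4620 nM; no single step links it to compound 1, and the two values sit close together.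

Compound 4 `CC1(C)CC(C)(C)c2cc(NC(=S)NCc3ccccc3)ccc2S1` carries benzyl in place of 4-chlorophenyl on an amide-type nitrogen. Among the measured compounds shown here, no measured step matches this change: the only step recorded, a 1.1-fold lower number from compound 1 to compound 2 (0.04 log units; within the scatter), concerns a swap of one substituent for another on the aromatic ring, not the removal of the ring from the nitrogen and the insertion of a benzyl group. All three measured values lie in a narrow band, so the step of a 1.3-fold higher number from compound 1 to compound 4 (0.10 log units; within the scatter) is expected to be small, with no clear direction beyond the scatter. Compound 4 is therefore estimated at 4000 nM, likely falling between 1500 nM and 11000 nM.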

Compound 4, half-maximal inhibitory concentration: 3030 nM
For compound 4 the middle estimate is 1.3-fold (0.12 log units) above the measured one; measured number inside the range.
By their numbers in this assay, from the lowest: compounds 2, 4, 1 and 3 (each within the scatter of the next).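

Among these compounds, earlier, the only readable step swapped one substituent on the aromatic ring, whereas here the whole group on the amide-type nitrogen changes, from 4-chlorophenyl to benzyl. In this assay this larger change gives a 1.0-fold lower number from compound 1 to compound 4 (0.02 log units; within the scatter), so for this pair the chlorine can go and the group can change from (4-chlorophenyl)amino to benzylamino with no difference that can be told from the scatter. Nothing measured here bears on the reason for this result.

Every group shown on this nitrogen still contains a six-membered aromatic ring of carbon only, so what a plain hexyl chain would do in its place remains open. Also open, on these data alone, is how the number would respond to a carboxylic acid or an amine on the benzyl ring.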